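Swapping Phenyl for Ethynyl on the Shared Core

The compounds below may be only part of what the source reports. "The series", "measured", "known", "first", "only" and "open" are said of these compounds alone.

In a functional assay on HCT-116 cells (Homo sapiens), read by MTT assay, with a stated time of 72 h (a lower number here means a stronger inhibitor, a higher number a weaker inhibitor), compound 3 (`CNc1ncnc2c1c(-c1ccccc1)cn2[C@@H]1O[C@H](CO)[C@@H](O)[C@H]1O`) gives > 100000 nM, which is a limit of the assay and not a number. Compound 2 (`CNc1ncnc2c1c(-c1ccoc1)cn2[C@@H]1O[C@H](CO)[C@@H](O)[C@H]1O`) gives > 20000 nM, which is also a limit. Compound 1 (`C#Cc1cn([C@@H]2O[C@H](CO)[C@@H](O)[C@H]2O)c2ncnc(SC)c12`) is the only one of the three with a true number, at 90 nM.

Compound 4 (`C#Cc1cn([C@@H]2O[C@H](CO)[C@@H](O)[C@H]2O)c2ncnc(NC)c12`) carries ethynyl in place of phenyl on an aromatic carbon.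

Going by the values given here, the one measured single change is a step that the two limits leave unreadable from compound 2 to compound 3, so it offers no size to carry over. The better guide is compound 1, which carries the same ethynyl group and reaches 90 nM in this assay. Among the compounds with values here, it also differs from compound 4 at a second place on the core, and no measured step shows what that second difference is worth. Stronger inhibition than compound 3 is therefore expected, probably without quite matching compound 1, and the uncertainty is wide.

The expected step is an at least 160-fold lower number from compound 3 to compound 4 (2.22 log units; beyond the scatter), a large one toward stronger inhibition.

For compound 4 the estimated value is 600 nM, with an expected range from 60 nM to 8000 nM.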

Compound 4, half-maximal inhibitory concentration: > 20000 nM
Compound 4 was reported as a limit; the forecaster's own chance of this, stated with the estimate: 20%; at least 33-fold (1.52 log units) between middle value and limit.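

Ethynyl alone does not carry the activity seen for compound 1. In this assay, compound 4 has ethynyl together with methylamino and gives > 20000 nM, which is a limit of the assay and not a number. With ethynyl kept, methylamino in place of methylsulfanyl on an aromatic carbon gives an at least 220-fold higher number from compound 1 to compound 4 (2.34 log units; beyond the scatter), so in this pair the strong value goes with methylsulfanyl. With methylamino on the core, the steps between ethynyl, phenyl and furan-3-yl cannot be read, and no order among these three groups can be given; the limit shared by two of these compounds is this one: the limit of > 20000 nM in this assay, at which 2 of the 4 values shown sit.

The compounds shown do not tell whether ethynyl itself matters when methylsulfanyl is present, which would take phenyl or furan-3-yl paired with methylsulfanyl on the same core. They also leave open how a plain amino group or a methoxy group would behave in place of methylsulfanyl, and so whether the strong value of compound 1 is special to methylsulfanyl or shared by other small groups on that aromatic carbon.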